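Removing a methoxy group: compound 1 to compound 4

This account rests on a few compounds, and the source may have more. Where it says the series, first, only, none or still open, it means among the compounds named here.

Of the compounds shown here, three sharing one core have been tested in a functional assay on the whole organism (strain BALB/c) for inhibition, with Mus musculus as the target, read by paw edema, with a stated time of 4 h, at a dose of 50 mg/kg by the oral route; a lower number here means less inhibition, a higher number more inhibition at the dose given (going by the name of the read-out). Compound 1 `COc1ccc(Nc2nnc(-c3cc(-c4ccc(F)cc4F)ccc3O)o2)cc1` gives 35.3% in this assay. Compound 2 `Oc1ccc(-c2ccc(F)cc2F)cc1-c1n[nH]c(=S)n1-c1ccccc1` gives 36.3%, and compound 3 `C=CCn1c(-c2cc(-c3ccc(F)cc3F)ccc2O)n[nH]c1=S` gives 73%. Compound 1 therefore stands lowest of the three, though its gap to compound 2 is within the scatter; only compound 3 is clearly apart from it.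

Going by the values given here, the single measured step is a number 36.7 percentage points higher from compound 2 to compound 3 (beyond the scatter). It concerns a substituent on an aromatic nitrogen and says nothing about the change now at hand.

Compound 4 `Oc1ccc(-c2ccc(F)cc2F)cc1-c1nnc(Nc2ccccc2)o1` differs from compound 1 as follows: hydrogen in place of methoxy on an aromatic carbon. Among the compounds with values here, no measured step bears on this change, so the expectation rests on compound 1 alone and on the fact that loss of a small group at the edge of the molecule has no precedent here. The expected step is a number 0.7 percentage points higher from compound 1 to compound 4 (within the scatter), that is, none beyond the scatter. Compound 4 is therefore estimated at 36%, within a range from 20% to 55%.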

Compound 4, a percentage reported as inhibition, in the whole organism at one dose (the size of the read-out at that dose, not a potency): 39.5%
For compound 4 the middle estimate is 3.5 percentage points below the measured one; the measured number falls inside the stated range.
By their numbers in this assay, from the lowest: compounds 1, 2 and 4 (each within the scatter of the next); then compound 3.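

Replacing methoxy with hydrogen on this aromatic carbon, para to a large group, gives a number 4.2 percentage points higher from compound 1 to compound 4 (within the scatter) in this assay, so this change from 4-methoxyphenyl to phenyl does not separate the two compounds. Going by these compounds alone, this is the first reading at this edge of the molecule, as the earlier step concerned a substituent on an aromatic nitrogen, and it shows that the response at this dose holds without the methoxy group. Nothing given here explains this result.

From the compounds shown here alone, it remains open whether another group at this place, such as an amine, a chlorine atom or a carboxylic acid, would move the number beyond the scatter. Also open, going by these compounds, is whether a longer chain such as ethoxy would leave the number as unchanged as hydrogen does.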